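The compounds below may be only part of what the source reports. "The series", "measured", "known", "first", "only" and "open" are said of these compounds alone.

Working notes on the series. In an ADME assay on Caco-2 cells (Homo sapiens) for permeability, read by LC-MS, in the apical to basolateral direction, with a stated time of 60 min, at pH 6.5 (a lower number here means that the compound crosses the layer more slowly, a higher number that the compound crosses the layer faster), compound 1 `CC1(C[C@@H](O)C(=O)N2N=CC[C@H]2C(=O)NCc2cc(Cl)ccc2-n2cnnn2)CC1` gives 9.5 10^-6 cm/s, compound 2 `CC(C)(C)[C@@H](O)C(=O)N1CSC(C)(C)[C@H]1C(=O)NCc1cc(Cl)ccc1-n1cnnn1` gives 6.2 10^-6 cm/s and compound 3 `CC(C)(C)[C@@H](O)C(=O)N1NCC[C@H]1C(=O)NCc1cc(Cl)ccc1-n1cnnn1` gives 7.2 10^-6 cm/s. These three numbers lie within the usual scatter of one another, so compound 1 stands level with compound 2 and compound 3 and not apart from them. Among the measured compounds shown here, no pair among the measured compounds differs in one place only, so no measured step is available as a guide.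

Compound 4 `COC(C)(C)[C@@H](O)C(=O)N1N=CC[C@H]1C(=O)NCc1cc(Cl)ccc1-n1cnnn1` has no number yet. It keeps the core of compound 1 and changes one group: 1-methoxy-1-methylethyl in place of (1-methylcyclopropyl)methyl on a saturated chain carbon bound to a carbonyl carbon and an oxygen on a saturated carbon. For the measured compounds named here, the only evidence is the narrow spread of the three values, anchored on compound 1 at 9.5 10^-6 cm/s. On that basis, no step beyond the scatter is expected in this assay, though the estimate leans slightly downward. The estimated change is a 1.4-fold lower number from compound 1 to compound 4 (0.13 log units; within the scatter), and it is expected to remain within the scatter. For compound 4 the expected value is 7 10^-6 cm/s, with an estimated range of 3.5 10^-6 cm/s to 14 10^-6 cm/s.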

Compound 4, apparent permeability: 1.7 10^-6 cm/s
The estimate for compound 4 lay 4.1-fold (0.61 log units) above the measured number; measured number below the stated range.
By their numbers in this assay, from the lowest: compound 4; then compounds 2, 3 and 1 (each within the scatter of the next).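

Among the compounds shown here, at the position on a saturated chain carbon bound to a carbonyl carbon and an oxygen on a saturated carbon, the choice of group does matter in this assay: 1-methoxy-1-methylethyl in place of (1-methylcyclopropyl)methyl gives a 5.6-fold lower number from compound 1 to compound 4 (0.75 log units; beyond the scatter), the only single-place step so far, and the narrow spread among the earlier compounds gave no sign of it. The heavy-atom count stays the same across this change, while the entering group brings an oxygen and a hydrogen-bond acceptor and has no ring, and the leaving group has a three-membered carbon ring and no acceptor. No available evidence indicates which of these differences accounts for the step.

The compounds shown leave open whether the step follows the oxygen or the loss of the ring, and whether it would hold on the cores of compound 2 and compound 3. Going by these compounds, how an amine or a longer ether chain at this position would stand in this assay also remains open.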